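Sulfur-linked side-chain variation on the shared core

The compounds below may be only part of what the source reports. "The series", "measured", "known", "first", "only" and "open" are said of these compounds alone.

Measured so far:
compound 1 `N#Cc1c(N)nc(SCC(=O)NCO)c(C#N)c1-c1ccc(OCC2CC2)cc1`: 8%
compound 2 `N#Cc1c(N)nc(SCn2cncn2)c(C#N)c1-c1ccc(OCC2CC2)cc1`: 1%

In an assay on CHO cells for displacement of a labelled ligand from adenosine receptor A3 (Homo sapiens), read by scintillation counting, with a stated time of 120 min, tested at 1 uM (a higher number here means more inhibition at the concentration tested (going by the name of the read-out), a lower number less inhibition), compound 1 gives 8% and compound 2 gives 1%. Compound 2 holds the lower of the two numbers, but its nearest neighbour compound 1 sits within the scatter of it, so the two cannot be ordered. Among the measured compounds shown here, the single measured step, a number 7 percentage points lower from compound 1 to compound 2 (within the scatter), exchanges the group on the saturated chain carbon bound to a sulfur and stays within the scatter.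

Compound 3 `CNC(=O)CSc1nc(N)c(C#N)c(-c2ccc(OCC3CC3)cc2)c1C#N` differs from compound 2 as follows: methylcarbamoyl in place of 1H-1,2,4-triazol-1-yl on a saturated chain carbon bound to a sulfur. The step from compound 1 to compound 2 is the only one that bears on this change, since it alters the same position; it was within the scatter. Both measured compounds are low in this assay, so for compound 3 no movement beyond the scatter is expected, a number 4 percentage points higher from compound 2 to compound 3 (within the scatter). Compound 3 is therefore estimated at 5%, within -5% to 15%.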

Compound 3, a percentage reported as inhibition, at one concentration (the size of the read-out at that concentration, not a potency): 3%
Compound 3: middle estimate off by 2 percentage points, on the high side; measured number inside the range.
By their numbers in this assay, from the lowest: compounds 2, 3 and 1 (each within the scatter of the next).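

Methylcarbamoyl in place of 1H-1,2,4-triazol-1-yl on a saturated chain carbon bound to a sulfur gives a number 2 percentage points higher from compound 2 to compound 3 (within the scatter), so in this assay this exchange of an aromatic ring for a group with no ring does not separate the two compounds. Within the amide side chain, hydrogen in place of hydroxy on a saturated chain carbon bound to an amide-type nitrogen gives a number 5 percentage points lower from compound 1 to compound 3 (within the scatter), so this second change does not separate its two compounds either. All three side chains on the shared core therefore stay within the scatter of one another. No evidence on hand bears on these readings.

From the compounds shown here alone, what a carboxylic acid, an amine or a longer chain would give at this place remains open. So does whether any group here can move the number beyond the scatter.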